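Swapping the Aryl Group on the Triazole Nitrogen

The source may report more compounds than this note shows. Statements on the series, on what has been measured and on what is new or still open speak of the compounds shown alone.

Compound 3 `Cc1ccc(-n2cc(CSC(=S)N3CCN(C(=O)OC(C)(C)C)CC3)nn2)cc1` carries a 4-methylphenyl on an aromatic nitrogen of its shared core, and in a functional assay on MGC-803 cells (Homo sapiens) for inhibition, read by MTT assay, with a stated time of 72 h (a higher number here means a weaker inhibitor, a lower number a stronger inhibitor), compound 3 gives 48300 nM. Its nearest relative, compound 1 `CC(C)(C)OC(=O)N1CCN(C(=S)SCc2cn(-c3ccccc3F)nn2)CC1`, differs only by a 2-fluorophenyl at that position, and in this assay compound 1 gives 119000 nM. Among the compounds with values here, the single measured step, a 2.5-fold lower number from compound 1 to compound 3 (0.39 log units; beyond the scatter), leaves compound 3 with the lower of the two numbers. A further compound, compound 2 `COc1ccc(Cn2cc(CSC(=S)N3CCNCC3)nn2)cc1`, has "not determined" (no result reported) in this assay; it already bears a 4-methoxybenzyl group but lacks a group found elsewhere in compounds 1 and 3, so it offers no number to lean on.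

Compound 4 `COc1ccc(Cn2cc(CSC(=S)N3CCN(C(=O)OC(C)(C)C)CC3)nn2)cc1` arises from compound 3 by 4-methoxybenzyl in place of 4-methylphenyl on an aromatic nitrogen. Within the data shown here, no measured step covers this exact exchange. Among the measured compounds shown here, the only step at this position, a 2.5-fold lower number from compound 1 to compound 3 (0.39 log units; beyond the scatter), was modest, and it compared two different aryl groups, not an aryl with a benzyl. The expectation therefore is a step no larger than the scatter, with no firm direction, and the estimated step is a 1.1-fold lower number from compound 3 to compound 4 (0.03 log units; within the scatter). Compound 4 is expected to give about 45000 nM in this assay, within a range from 15000 nM to 130000 nM.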

Compound 4, half-maximal inhibitory concentration: 22800 nM
For compound 4 the middle estimate is 2.0-fold (0.30 log units) above the measured one, within the range that was stated.
By their numbers in this assay, from the lowest: compound 4; then compound 3; then compound 1.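

The earlier step compared two phenyl groups, whereas this one shows that a benzyl group is also accepted on the aromatic nitrogen, and that the number can fall further with it. In this assay, the move from 4-methylphenyl to 4-methoxybenzyl gives a 2.1-fold lower number from compound 3 to compound 4 (0.33 log units; beyond the scatter) and stays beyond the usual scatter, while the larger move from 2-fluorophenyl to 4-methoxybenzyl gives a 5.2-fold lower number from compound 1 to compound 4 (0.72 log units; beyond the scatter) and makes compound 4 the strongest inhibitor of these three. Nothing shown accounts for these differences.

As far as these compounds go, the exchange from compound 3 to compound 4 alters two features at once, the link to the ring and the ring's substituent, which changes from methyl to methoxy, so the share of each remains unknown. A 4-methylbenzyl or 4-methoxyphenyl group would pull these two features apart, and an unsubstituted benzyl or a 4-aminobenzyl group would show whether the methoxy oxygen matters at all.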